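Changing one amide group: what to expect for compound 3

This account rests on a few compounds, and the source may have more. Where it says the series, first, only, none or still open, it means among the compounds named here.

- compound 1 `O=C(N[C@H]1CN(S(=O)(=O)c2ccccc2)C[C@@H]1C(=O)N1C[C@H]2CCNC[C@H]21)c1cc(-c2ccccc2Cl)on1` gives 265000 nM
- compound 2 `O=C(N[C@H]1CN(S(=O)(=O)c2ccccc2)C[C@@H]1C(=O)NC[C@@H]1CCCN1)c1cc(-c2ccccc2Cl)on1` gives 503000 nM

Both numbers come from a physicochemical assay for solubility, at pH 7.4; a higher number here means a more soluble compound, a lower number a less soluble compound. Compound 2 lies within the scatter of compound 1, so these two measurements cannot be separated. Compound 3 `O=CN1CCC[C@H](NC(=O)[C@H]2CN(S(=O)(=O)c3ccccc3)C[C@@H]2NC(=O)c2cc(-c3ccccc3Cl)on2)C1` has not yet been measured. It keeps the core of compound 2 and changes one group on an amide-type nitrogen (a group of 8 heavy atoms (6 carbon, 1 nitrogen, 1 oxygen; one six-membered non-aromatic ring with 1 hetero atom) in place of a group of 6 heavy atoms (5 carbon, 1 nitrogen; one five-membered non-aromatic ring with 1 hetero atom), on an amide-type nitrogen).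

Among the compounds with values here, only one measured step bears on this change (a 1.9-fold higher number from compound 1 to compound 2 (0.28 log units; within the scatter)). That step also exchanges one ring-bearing group for another, and it stays within the scatter. Within the data shown here, it is a weak guide, however, since no measured compound carries the group that enters in compound 3. Compound 2, at 503000 nM, sits high enough that a fall seems likelier than a rise, although the data cannot settle this. A moderate fall in this assay is therefore expected, possibly beyond the scatter (a 3.9-fold lower number from compound 2 to compound 3 (0.59 log units; beyond the scatter)). The estimate for compound 3 is 130000 nM, with an expected range from 30000 nM to 450000 nM (a wide range, given so little evidence).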

Compound 3, solubility: 4500 nM
Beside the measured number, compound 3's estimate is 29-fold (1.46 log units) above it, outside the stated range (below it).
By their numbers in this assay, from the lowest: compound 3; then compounds 1 and 2 (each within the scatter of the next).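

In this assay, within the data shown here, the group on this amide-type nitrogen turns out to matter a great deal: replacing (pyrrolidin-2-yl)methyl with the six-membered ring group gives a 110-fold lower number from compound 2 to compound 3 (2.05 log units; beyond the scatter), a large step where the only earlier step stayed within the scatter. Compound 3 also stands well apart from the other measured compound, with a 59-fold lower number from compound 1 to compound 3 (1.77 log units; beyond the scatter), so the shared core alone does not keep the number high, and compound 3 is the lowest of the three. The change swaps a five-membered ring for a six-membered one, adds a double bond outside aromatic rings and goes from 1 hydrogen-bond donor to 0, and no measurement shown here explains the fall.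

Since these differences arrive together in a single step, the compounds shown leave open which of them goes with the drop. A six-membered ring carrying a plain amine in place of the entering group, or a pyrrolidine ring carrying the same double-bonded group, would separate the ring from the rest of the change.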